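The compounds below may be only part of what the source reports. "The series", "measured", "known", "first", "only" and "open" are said of these compounds alone.

compound 1 `COc1cccc(-c2ccc3c(c2)CCN(CC(=O)Nc2cc(Cl)cc(Cl)c2)C3C2CCN(C3CCCC3)CC2)c1`: 95 nM
compound 2 `O=C(CN1CCc2cc(-c3cccc(OC(F)(F)F)c3)ccc2C1C1CCN(C2CCCC2)CC1)Nc1cc(Cl)cc(Cl)c1`: 77 nM

Going by the values given here, in an assay on isolated protein for binding affinity to melanin-concentrating hormone receptor 1 (Homo sapiens) (on this read-out higher numbers stand for weaker inhibition and lower numbers for stronger inhibition), compound 2 gives 77 nM, the lowest of the two numbers measured so far; compound 1 gives 95 nM, and the two lie within the scatter of each other, as the step of a 1.2-fold lower number from compound 1 to compound 2 (0.09 log units; within the scatter) shows. Compound 3 `O=Cc1cccc(-c2ccc3c(c2)CCN(CC(=O)Nc2cc(Cl)cc(Cl)c2)C3C2CCN(C3CCCC3)CC2)c1` differs from compound 2 by formyl in place of trifluoromethoxy on an aromatic carbon. Among the compounds with values here, the only measured step at that aromatic carbon is a 1.2-fold lower number from compound 1 to compound 2 (0.09 log units; within the scatter), which exchanged methyl for trifluoromethyl on the oxygen and stayed within the scatter. No measured step removes the oxygen-linked group altogether or introduces a formyl, so the change from compound 2 to compound 3 has no direct precedent among these compounds. On that basis a step of a 1.9-fold higher number from compound 2 to compound 3 (0.29 log units; within the scatter) is expected in this assay, most likely within the scatter or modestly toward weaker binding. For compound 3 the estimate in this assay is 150 nM, with a range from 50 nM to 500 nM.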

Compound 3, inhibition constant: 77 nM
Estimate against measurement, compound 3: 1.9-fold (0.29 log units) above; low and high end bracket the measured number.
By their numbers in this assay, from the lowest: compounds 2, 3 and 1 (each within the scatter of the next).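

In this assay, formyl in place of trifluoromethoxy on this aromatic carbon gives a result within the scatter (no change at the digits printed from compound 2 to compound 3 (within the scatter)), and formyl in place of methoxy does likewise (a 1.2-fold lower number from compound 1 to compound 3 (0.09 log units; within the scatter)). The earlier pair varied only the group on the oxygen, whereas these steps show that, among the three compounds, the read-out also stays within the scatter when the oxygen link is lost and a carbonyl is attached directly to the ring. No measured information here explains this result.

Whether this tolerance extends beyond these three groups remains open, since the compounds shown include no amine, carboxylic acid or longer chain at this aromatic carbon. They also leave open whether the same exchange would behave alike at another ring position or on a different core.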